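Methyl Removal in a Small Cytotoxic Series

The source may hold more compounds than are shown below. What is called first, only, known or untested is meant among the compounds shown, and "the series" means these compounds.

Measured compounds:
Compound 1 `Cc1ccc2[nH]c(-c3ccc[nH]3)c(C3CC(=O)NC3=O)c2c1` — 11000 nM
Compound 2 `Cc1ccc2[nH]c3c(c4c(c5ccnn53)C(=O)NC4=O)c2c1` — 75000 nM

In a functional assay on PC-3 cells (Homo sapiens) for cytotoxicity, read by MTT assay, with a stated time of 72 h (on this read-out higher numbers stand for weaker inhibition and lower numbers for stronger inhibition), compound 1 gives 11000 nM. This is the lowest of the two numbers recorded so far; compound 2 gives 75000 nM, a higher number that lies beyond the usual scatter of the measurement, so compound 1 stands as the stronger inhibitor of the pair.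

Compound 3 `O=C1CC(c2c(-c3ccc[nH]3)[nH]c3ccccc23)C(=O)N1` has not yet been measured in this assay. It differs from compound 1 in one place: hydrogen in place of methyl on an aromatic carbon. Among the measured compounds shown here, no measured pair in this set shows what hydrogen in place of methyl does here, so the size of the step cannot be read from the data. Loss of a single carbon with no change in ring count, donors or acceptors is expected to give a step from compound 1 to compound 3 of no more than the scatter, in either direction: a 1.2-fold higher number from compound 1 to compound 3 (0.07 log units; within the scatter) is the expected step. Compound 3 is therefore estimated at 13000 nM, within a range of 5000 nM to 35000 nM.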

Compound 3, half-maximal inhibitory concentration: 9000 nM
Compound 3: middle estimate off by 1.4-fold (0.16 log units), on the high side; measured number inside the range.
By their numbers in this assay, from the lowest: compounds 3 and 1 (each within the scatter of the next); then compound 2.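

In this assay, among the compounds shown here, hydrogen in place of methyl on an aromatic carbon gives a 1.2-fold lower number from compound 1 to compound 3 (0.09 log units; within the scatter) and so provides the first direct reading of this change. At this position, on the six-membered aromatic ring of carbon only, the methyl is not needed to keep the number at this level, and the assay does not separate compound 1 from compound 3. Nothing measured here gives a reason for this result.

What the compounds leave open is whether another group on this aromatic carbon, such as a methoxy group, an amine or a carboxylic acid, would move the number beyond the scatter. They also leave open whether the same change would give a similar step on the core of compound 2.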